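The source may report more compounds than this note shows. Statements on the series, on what has been measured and on what is new or still open speak of the compounds shown alone.

For the measured compounds named here, compound 1, with the structure `Nc1nc(N/N=C/c2ccc[nH]2)nc2c1ncn2[C@@H]1O[C@H](CO)[C@@H](O)[C@H]1O`, is one of two compounds measured in an assay on CHO-K1 cells for displacement of a labelled ligand from adenosine receptor A1 (Homo sapiens), read by scintillation counting, with a stated time of 60 min; on this read-out higher numbers stand for weaker inhibition and lower numbers for stronger inhibition. In this assay compound 1 gives 8 nM, the lowest of the two numbers. The other measured compound, compound 2, has the structure `Nc1nc(N/N=C/c2ccc(-c3ccccn3)cc2)nc2c1ncn2[C@@H]1O[C@H](CO)[C@@H](O)[C@H]1O` and in this assay gives 7540 nM, a far higher number than that of compound 1, a gap well beyond the usual scatter. Going by the values given here, no single-point step between the two measured compounds is available, so the pair shows only that a larger aromatic group at the hydrazone carbon goes with much weaker binding.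

Compound 3, with the structure `CSCC/C=N/Nc1nc(N)c2ncn([C@@H]3O[C@H](CO)[C@@H](O)[C@H]3O)c2n1`, has not yet been measured in this assay. Compared with compound 1, the change is 2-(methylsulfanyl)ethyl in place of 1H-pyrrol-2-yl on a carbon with a double bond to nitrogen. The aromatic ring with its hydrogen-bond donor gives way to a short flexible chain carrying a sulfur acceptor. Because compound 1 gives 8 nM, and because the bulkier aromatic change in compound 2 gives 7540 nM, a loss of binding strength is expected here too, though a smaller one. The step is estimated as a 19-fold higher number from compound 1 to compound 3 (1.27 log units; beyond the scatter), in the direction of a higher number. For compound 3 the expected result is 150 nM, with a likely range from 20 nM to 1500 nM.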

Compound 3, inhibition constant: > 10000 nM
Compound 3: only a limit was reported (the forecaster's own chance of this, stated with the estimate: 5%); middle value at least 66-fold (1.82 log units) away from the limit.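

The result for compound 3 in this assay is a limit of the assay and not a number: the limit of > 10000 nM in this assay, at which 1 of the 3 values shown sits. Putting 2-(methylsulfanyl)ethyl in place of 1H-pyrrol-2-yl on a carbon with a double bond to nitrogen gives an at least 1200-fold higher number from compound 1 to compound 3 (3.09 log units; beyond the scatter), so this single change takes the strong binding of compound 1 out of reach of the measured range. The earlier compounds shown here linked weak binding only to a larger aromatic group, whereas here the entering group has 4 heavy atoms against the 5 that leave, which shows that a bigger group is not needed for binding to be lost at this place.

The change removes the five-membered aromatic ring and the hydrogen-bond donor together, and it also brings in sulfur, so the compounds shown cannot tell which of these matters for the loss. Also open, on these data alone, is how binding would respond to a furan-2-yl group, which keeps a five-membered aromatic ring but has oxygen as its hetero atom, or to a plain butyl chain, which has no sulfur.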